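A Longer Ester on a Potent Compound

The source may report more compounds than this note shows. Statements on the series, on what has been measured and on what is new or still open speak of the compounds shown alone.

Compound 1 `COC(=O)c1nn([C@@H]2O[C@H](CO)[C@@H](O)[C@H]2O)cc1I` gives 200 nM
Compound 2 `C#Cc1cn([C@@H]2O[C@H](CO)[C@@H](O)[C@H]2O)nc1C(N)=O` gives > 300000 nM as a limit

Among the compounds with values here, in a functional assay on Raji cells (Homo sapiens) (a lower number here means a stronger inhibitor, a higher number a weaker inhibitor), compound 1 gives 200 nM as the only exact number available. Compound 2 reads > 300000 nM as a limit of the assay and not a number. Compound 3 `CCCCOC(=O)c1nn([C@@H]2O[C@H](CO)[C@@H](O)[C@H]2O)cc1I` turns the methoxycarbonyl of compound 1 into butoxycarbonyl propyl in place of hydrogen on a saturated chain carbon bound to an oxygen next to a carbonyl group and leaves the shared core unchanged. Within the data shown here, no measured pair shows such a change, so the expectation in this assay rests on compound 1 at 200 nM alone. The expected step of a 3.0-fold higher number from compound 1 to compound 3 (0.48 log units; beyond the scatter) is a modest weakening. Compound 3 is estimated at 600 nM with a range of 100 nM to 5000 nM expected to hold the measurement.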

Compound 3, half-maximal inhibitory concentration: 17000 nM
Beside the measured number, compound 3's estimate is 28-fold (1.45 log units) below it; the measured number lies above the stated range.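

In this assay this ester position proves sensitive to chain length: changing methoxycarbonyl to butoxycarbonyl gives an 85-fold higher number from compound 1 to compound 3 (1.93 log units; beyond the scatter), with the shared core unchanged. Within the data shown here, this is the only measured step at this position, and it shows that propyl in place of hydrogen on this saturated chain carbon costs much of the activity of compound 1. Nothing measured here explains the size of this loss. Still open, on these data alone, is how an ethoxycarbonyl group, with a chain between methyl and butyl, would read, and whether a carboxylic acid could replace the ester.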